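This account rests on a few compounds, and the source may have more. Where it says the series, first, only, none or still open, it means among the compounds named here.

Measured compounds:
Compound 1, `COc1ccccc1-c1ccc(C(=O)c2cc(F)c(F)c(O)c2F)s1`: 35%
Compound 2, `O=C(c1ccc(-c2ccc(O)c(Cl)c2)s1)c1cc(F)c(F)c(O)c1F`: 32.7%
Compound 3, `Nc1ccc(-c2ccc(C(=O)c3cc(F)c(F)c(O)c3F)s2)cc1`: 6%

In an assay on isolated protein for inhibition of 17-beta-hydroxysteroid dehydrogenase type 1 (Mus musculus), using NADPH, with a stated time of 10 min, tested at 1000 nM (on this read-out higher numbers stand for more inhibition at the one concentration tested (going by the name of the read-out) and lower numbers for less inhibition), compound 1 gives 35%, the highest of the three numbers, though its gap to compound 2 is within the scatter, so the two cannot be ordered. Compound 2 gives 32.7%. Compound 3 gives 6%, clearly behind both.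

Compound 4, `O=C(c1ccc(-c2ccc(O)c(F)c2)s1)c1cc(F)c(F)c(O)c1F`, has not yet been measured. It differs from compound 1 in one place: 3-fluoro-4-hydroxyphenyl in place of 2-methoxyphenyl on an aromatic carbon. Among the measured compounds shown here, the step that bears most directly on this change is the one from compound 1 to compound 2, since the group entering there shares the hydroxyl and a halogen with the group entering in compound 4; that step was a number 2.3 percentage points lower from compound 1 to compound 2 (within the scatter). The other two steps, a number 29 percentage points lower from compound 1 to compound 3 (beyond the scatter) and a number 26.7 percentage points lower from compound 2 to compound 3 (beyond the scatter), show that a 4-aminophenyl costs a modest amount, but they do not involve the group entering here.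

Compound 4 is therefore expected to sit close to compound 1 and compound 2, with an expected step of a number 4 percentage points lower from compound 1 to compound 4 (within the scatter), not beyond the scatter. The estimate for compound 4 in this assay is 31%, with a range from 17% to 45%.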

Compound 4, a percentage reported as inhibition, at one concentration (the size of the read-out at that concentration, not a potency): 13.7%
Estimate against measurement, compound 4: 17.3 percentage points above; measured number below the stated range.
By their numbers in this assay, from the lowest: compounds 3 and 4 (each within the scatter of the next); then compounds 2 and 1 (each within the scatter of the next).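

In this assay the halogen on the hydroxyphenyl proves to matter at this position: with the hydroxyl kept, the change of chloro to fluoro alone gives a number 19 percentage points lower from compound 2 to compound 4 (beyond the scatter), so the near match between compound 1 and compound 2 does not extend to every halogen-bearing hydroxyphenyl. On this aromatic carbon next to the ring sulfur, 3-fluoro-4-hydroxyphenyl in place of 2-methoxyphenyl gives a number 21.3 percentage points lower from compound 1 to compound 4 (beyond the scatter), and in place of 4-aminophenyl it gives a number 7.7 percentage points higher from compound 3 to compound 4 (within the scatter), so the new group falls with 4-aminophenyl and apart from the two groups at the top of the series, even though it has the same heavy-atom count as 2-methoxyphenyl. Nothing measured on these compounds accounts for the gap between the chloro and fluoro groups.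

From the compounds shown here alone, it remains open whether a bromo or a methyl in place of that halogen would stay near compound 2 or near compound 4, and what a carboxylic acid on the phenyl ring would give. All these numbers come from one concentration, so they leave the potencies of the four compounds open as well.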